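Swapping the Heterocycle on Sulfur in a Fluorophenyl Hydrazone

The source may report more compounds than this note shows. Statements on the series, on what has been measured and on what is new or still open speak of the compounds shown alone.

Compound 2 `O=C(CSc1ncccn1)N/N=c1/scc(-c2ccc(F)cc2)n1-c1ccccc1` gives 32.2% in a functional assay on C6 cells (Rattus norvegicus) for cytotoxicity, read by MTT assay, with a stated time of 24 h, tested at 200 ug/mL (a lower number here means a stronger effect, a higher number a weaker effect of the compound at the concentration tested), the lowest of the three numbers measured; compound 1 `O=C(CSc1ncccn1)N/N=c1/scc(-c2ccc(Br)cc2)n1-c1ccccc1` gives 63.2% and compound 3 `Cn1cnnc1SCC(=O)N/N=c1/scc(-c2ccc(C#N)cc2)n1-c1ccccc1` gives 52.6% in this assay. Going by the values given here, the only single-site step known, a number 31 percentage points lower from compound 1 to compound 2 (beyond the scatter), concerns the halogen on the aromatic ring, not the heterocycle on sulfur. Compound 4 `Cc1nnc(SCC(=O)N/N=c2/scc(-c3ccc(F)cc3)n2-c2ccccc2)s1` differs from compound 2 by 5-methyl-1,3,4-thiadiazol-2-yl in place of pyrimidin-2-yl on a sulfur. Compound 3 carries both another heterocycle and a nitrile, so its number cannot be split into a step for this change alone. Among the compounds with values here, no measured step therefore bears on this change, and no step beyond the scatter is expected in either direction. Compound 4 is expected to give 38%, within 20% to 62%, an estimated step of a number 5.8 percentage points higher from compound 2 to compound 4 (within the scatter).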

Compound 4, a percentage reported as activity, at one concentration (the size of the read-out at that concentration, not a potency): 26.5%
The estimate for compound 4 lay 11.5 percentage points above the measured number; low and high end bracket the measured number.
By their numbers in this assay, from the lowest: compounds 4 and 2 (each within the scatter of the next); then compound 3; then compound 1.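

Going by these compounds alone, at the sulfur, this assay records a number 5.7 percentage points lower from compound 2 to compound 4 (within the scatter) for the first single-site change at this position, where the earlier step concerned the halogen on the aromatic ring. The six-membered pyrimidin-2-yl can thus give way to the five-membered 5-methyl-1,3,4-thiadiazol-2-yl, with the fluoro group kept, without a step beyond the scatter. Nothing measured here explains this outcome. Going by these compounds, whether the exchange would read alike with bromo in place of fluoro stays open. So does the effect of an amine or a carboxylic acid in place of the heterocycle on sulfur.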